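Swapping the group on sulfur in compound 1

The source may hold more compounds than are shown below. What is called first, only, known or untested is meant among the compounds shown, and "the series" means these compounds.

In a functional assay on A549 cells (Homo sapiens) for inhibition, read by CCK-8 assay, with a stated time of 72 h, tested at 2 uM (a lower number here means less inhibition of growth, a higher number more inhibition of growth at the concentration tested), compound 1 (`COc1ccc(SCc2ccc(C(=O)Nc3ccccc3N)cc2)cc1`) gives 45.7%. Compound 2 (`Cc1ccc(SCc2ccc(/C=C/C(=O)Nc3ccccc3N)cc2)cc1`) gives 43.4%, within the scatter of compound 1. Compound 3 (`COc1ccc(SCc2ccc(C(=O)Nc3ccccc3N)cc2)cc1OC`) gives 19.9%, beyond the scatter from compound 1. Compound 4 (`Cc1cc(C)cc(SCc2ccc(C(=O)Nc3ccccc3N)cc2)c1`) is not yet measured. Its change is 3,5-dimethylphenyl in place of 4-methoxyphenyl on a sulfur. For the measured compounds named here, one measured step bears on it: a number 25.8 percentage points lower from compound 1 to compound 3 (beyond the scatter), with methoxy in place of hydrogen on an aromatic carbon. That step is modest and does not match this swap, so only a smaller fall is expected, and no change is not excluded. The expected step is a number 9.7 percentage points lower from compound 1 to compound 4 (within the scatter). For compound 4 the estimated value is 36%, with an expected range of 16% to 56%.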

Compound 4, percent growth inhibition at one concentration: 33.3%
Compound 4: middle estimate off by 2.7 percentage points, on the high side, and the stated range covers the measured number.
By their numbers in this assay, from the lowest: compound 3; then compound 4; then compounds 2 and 1 (each within the scatter of the next).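

With a carbon-only aryl group on the sulfur, growth inhibition is reduced but not lost: in this assay, a number 12.4 percentage points lower from compound 1 to compound 4 (beyond the scatter). Compound 4 gives 33.3% with 3,5-dimethylphenyl, which has no hydrogen-bond acceptor and the same heavy-atom count as 4-methoxyphenyl, so a methoxy on this aryl group is not required for activity at this concentration. Nothing available accounts for the lower number. Open, as far as these compounds go, is how an amine, a carboxylic acid or a longer chain would read on this sulfur, and whether a single methyl group would match either aryl group.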